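This account rests on a few compounds, and the source may have more. Where it says the series, first, only, none or still open, it means among the compounds named here.

Of the compounds shown here, three built on one shared core have been measured in a functional assay on HCT-116 cells (Homo sapiens) for inhibition, read by MTT assay, with a stated time of 48 h (a higher number here means a weaker inhibitor, a lower number a stronger inhibitor), where the read-out is a half-maximal inhibitory concentration. Compound 1, `COc1ccc(N(C)c2nc(C)nc3ccccc23)cc1C(=O)OCCCCC[Se]C#N`, gives 551 nM. Compound 2, `C[Se]c1ccc(N(C)c2nc(C)nc3ccccc23)cc1C`, gives 3 nM, and compound 3, `COc1ccc(N(C)c2nc(C)nc3ccccc23)cc1[Se]C#N`, gives 34 nM. Compound 1 thus stands with the highest number of the three, and its distance to each of the other two lies beyond the usual scatter; compound 3 is the nearest to it and compound 2 the furthest.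

The step under consideration leads from compound 1 to compound 4, `COc1ccc(N(C)c2nc(C)nc3ccccc23)cc1C(=O)OCCCCCC[Se]C#N`, which has not yet been measured. The change is this: a group of 4 heavy atoms (2 carbon, 1 nitrogen, 1 selenium; no ring) in place of a group of 3 heavy atoms (1 carbon, 1 nitrogen, 1 selenium; no ring), on a saturated chain carbon, five bonds along the chain from an oxygen next to a carbonyl group. Among the compounds with values here, no pair of measured compounds differs in one place, so no measured step shows what a change of this kind does in this assay. The groups leaving and entering are alike in kind. The expected step is small, in no particular direction, and within the scatter. Compound 4 is accordingly estimated at 500 nM, with a range from 200 nM to 1500 nM. The estimated step from compound 1 to compound 4 is a 1.1-fold lower number from compound 1 to compound 4 (0.04 log units; within the scatter), which is expected to stay inside the scatter.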

Compound 4, half-maximal inhibitory concentration: 1990 nM
Estimate against measurement, compound 4: 4.0-fold (0.60 log units) below; measured number above the stated range.
By their numbers in this assay, from the lowest: compound 2; then compound 3; then compound 1; then compound 4.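

In this assay, within the data shown here, putting a group of 4 heavy atoms in place of a group of 3 heavy atoms, on a saturated chain carbon, five bonds along the chain from an oxygen next to a carbonyl group, gives a 3.6-fold higher number from compound 1 to compound 4 (0.56 log units; beyond the scatter), the first step that can be read. It shows that this position is not indifferent to a change between groups alike in kind: the extended chain goes with a weaker inhibitor, by a modest step beyond the scatter. Nothing measured here explains this step.

Going by these compounds, one step sets no trend, so it remains open whether a longer chain would continue in this direction or a shorter chain reverse it. On these data alone, it also remains open how an amine or a carboxylic acid at the end of the chain would compare.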